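This account rests on a few compounds, and the source may have more. Where it says the series, first, only, none or still open, it means among the compounds named here.

Measured compounds:
- compound 1 `COc1cccc(-c2c(C)nn(-c3nc(-c4ccc(Cl)c(Cl)c4)c(SC(C)C)s3)c2C(=O)O)c1` gives 14000 nM
- compound 2 `Cc1ccccc1-c1c(C)nn(-c2nc(-c3ccc(Cl)c(Cl)c3)c(SC(C)C)s2)c1C(=O)O` gives 5500 nM
- compound 3 `COc1ccccc1-c1c(C)nn(-c2nc(-c3ccc(Cl)c(Cl)c3)c(SC(C)C)s2)c1C(=O)O` gives 14700 nM

These three numbers come from a functional assay on BJAB cells (Homo sapiens) for antiproliferative activity, with a stated time of 4 days; on this read-out lower numbers stand for an effect already at smaller amounts and higher numbers for an effect only at larger amounts of compound. Compound 3 stands at the highest number of the three; one of the steps ending there is a 1.1-fold higher number from compound 1 to compound 3 (0.02 log units; within the scatter), which is within the scatter, while the other is a 2.7-fold higher number from compound 2 to compound 3 (0.43 log units; beyond the scatter), a modest step beyond the scatter.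

Compound 4 `Cc1cc(-c2c(C)nn(-c3nc(-c4ccc(Cl)c(Cl)c4)c(SC(C)C)s3)c2C(=O)O)cc(C)n1` is not yet measured. It differs from compound 3 by 2,6-dimethylpyridin-4-yl in place of 2-methoxyphenyl on an aromatic carbon. Within the data shown here, none of the measured steps swaps a phenyl for a pyridine, so the evidence bearing on this change is indirect. The steps that come closest are a 2.7-fold higher number from compound 2 to compound 3 (0.43 log units; beyond the scatter) and a 2.5-fold lower number from compound 1 to compound 2 (0.41 log units; beyond the scatter), both modest, which show that exchanging or moving small groups on this ring shifts this assay by modest amounts only. A similar, modest step is therefore expected for compound 4, with the direction uncertain; a slight move toward a lower number seems somewhat more likely, given that compound 2 gives 5500 nM with a methyl on this ring.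

Compound 4 is estimated at 9000 nM, with a range from 3000 nM to 27000 nM.

The expected step from compound 3 is a 1.6-fold lower number from compound 3 to compound 4 (0.21 log units; within the scatter).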

Compound 4, half-maximal effective concentration: 580 nM
The estimate for compound 4 lay 16-fold (1.19 log units) above the measured number, and the stated range ends above it.
By their numbers in this assay, from the lowest: compound 4; then compound 2; then compounds 1 and 3 (each within the scatter of the next).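

In this assay, among these compounds, the group on this aromatic carbon matters far more than the earlier compounds suggested: the new result gives a 25-fold lower number from compound 3 to compound 4 (1.40 log units; beyond the scatter), a 9.5-fold lower number from compound 2 to compound 4 (0.98 log units; beyond the scatter) and a 24-fold lower number from compound 1 to compound 4 (1.38 log units; beyond the scatter), each larger than any step among the three compounds with a phenyl ring. The change replaces a ring of carbon only with a ring holding a hetero atom, and it also brings in two methyl groups, while the heavy-atom and hydrogen-bond acceptor counts stay the same. Nothing measured here explains the gain.

Still open, as far as these compounds go, is whether the ring nitrogen, the two methyl groups or only their combination accounts for the lower number. A pyridinyl ring without methyl groups and a dimethylphenyl ring on this carbon would help to separate those contributions.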